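Amide to sulfonamide on the shared core

This account rests on a few compounds, and the source may have more. Where it says the series, first, only, none or still open, it means among the compounds named here.

Of the compounds shown here, three with a shared core have been measured in a functional assay on A-375 cells (Homo sapiens) for cytotoxicity, read by MTT assay; a higher number here means a weaker inhibitor, a lower number a stronger inhibitor. Compound 1 `O=C(NCCCNc1nccc(-c2c(-c3cccc(F)c3)nc3sccn23)n1)c1ccc(F)cc1` gives 14900 nM and compound 2 `O=C(NCCCNc1nccc(-c2c(-c3cccc(F)c3)nc3sccn23)n1)c1ccc(Cl)cc1` gives 13700 nM; the step of a 1.1-fold lower number from compound 1 to compound 2 (0.04 log units; within the scatter) shows that chloro in place of fluoro changed nothing that can be told apart. Compound 3 `O=C(NCCNc1nccc(-c2c(-c3cccc(F)c3)nc3sccn23)n1)c1ccccc1` gives 5060 nM, the lowest of the three numbers, with a 2.9-fold lower number from compound 1 to compound 3 (0.47 log units; beyond the scatter) and a 2.7-fold lower number from compound 2 to compound 3 (0.43 log units; beyond the scatter) both modest but beyond the scatter.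

Compound 4 `O=S(=O)(NCCNc1nccc(-c2c(-c3cccc(F)c3)nc3sccn23)n1)c1cccc(F)c1` differs from compound 3 in one place: (3-fluorophenyl)sulfonyl in place of benzoyl on an amine nitrogen. Within the data shown here, no measured step concerns the group on that amine nitrogen beyond the halogen swap of a 1.1-fold lower number from compound 1 to compound 2 (0.04 log units; within the scatter), which lay within the scatter, so nothing among the measured steps speaks for a move in either direction. The expected step is therefore a 1.3-fold higher number from compound 3 to compound 4 (0.11 log units; within the scatter), with a wide range. Compound 4 is estimated at 6500 nM, between 2000 nM and 22000 nM.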

Compound 4, half-maximal inhibitory concentration: 14900 nM
Beside the measured number, compound 4's estimate is 2.3-fold (0.36 log units) below it; low and high end bracket the measured number.
By their numbers in this assay, from the lowest: compound 3; then compounds 2, 1 and 4 (each within the scatter of the next).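

In this assay, (3-fluorophenyl)sulfonyl in place of benzoyl on the amine nitrogen gives a 2.9-fold higher number from compound 3 to compound 4 (0.47 log units; beyond the scatter), so a change at this position can move the number beyond the scatter, which the halogen swap on the benzoyl ring of the earlier amides had not shown. The other two comparisons, a 1.1-fold higher number from compound 2 to compound 4 (0.04 log units; within the scatter) and no change at the digits printed from compound 1 to compound 4 (within the scatter), both lie within the scatter, which leaves compound 3 alone with a lower number than each of the other three compounds. Nothing measured here bears on what lies behind the step.

As far as these compounds go, the change brings in the sulfonyl and the fluorine together, so their shares in the step stay open. A plain phenylsulfonyl group and a 3-fluorobenzoyl group on the same amine nitrogen would separate them.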